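Sulfamoyl in Place of Cyano on a Long-Lasting Compound

The source may hold more compounds than are shown below. What is called first, only, known or untested is meant among the compounds shown, and "the series" means these compounds.

In an ADME assay on the whole organism for metabolic stability, with Rattus norvegicus as the target, at a dose of 0.2 mg/kg by the intravenous route (a lower number here means that the compound disappears faster, a higher number that the compound lasts longer), compound 1 `NS(=O)(=O)c1ccc(OCCCN2CCC(C(O)(c3cccc(F)c3)c3nccs3)CC2)cc1` gives 1.4 h as its half-life, and compound 2 `N#Cc1ccc(OCCCN2CCC(C(O)(c3ccccn3)c3nccs3)CC2)cc1` gives 10.1 h as its half-life. Among the compounds with values here, compound 2 therefore stands highest of the two numbers so far, and the gap down to compound 1 lies beyond the scatter.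

Compound 3 `NS(=O)(=O)c1ccc(OCCCN2CCC(C(O)(c3ccccn3)c3nccs3)CC2)cc1` differs from compound 2 in one place, with sulfamoyl in place of cyano on an aromatic carbon, para to a large group (sulfamoyl in place of cyano on an aromatic carbon). Within the data shown here, no measured pair of compounds shows this change on its own, so its size in this assay cannot be read directly. Among the measured compounds shown here, the only guide is compound 1, which also carries the 4-sulfamoylphenoxy group and gives 1.4 h as its half-life, although it differs from compound 3 elsewhere. A fall beyond the scatter is therefore expected, but probably not one that reaches all the way down to compound 1. The estimated step runs a 2.5-fold lower number from compound 2 to compound 3 (0.40 log units; beyond the scatter) as a lower number. For compound 3 the estimated half-life is 4 h with an expected range from 1.8 h to 9 h around it.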

Compound 3, half-life: 2.5 h
The estimate for compound 3 lay 1.6-fold (0.20 log units) above the measured number; the range from low to high includes it.
By their numbers in this assay, from the lowest: compounds 1 and 3 (each within the scatter of the next); then compound 2.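

With the rest of the core held constant, the change from cyano to sulfamoyl on the aromatic carbon para to a large group now has a measured size in this assay: a 4.0-fold lower number from compound 2 to compound 3 (0.61 log units; beyond the scatter). The half-life at this position therefore responds to the group placed there, and the 4-cyanophenoxy compound 2 keeps the highest number of the three. The second new pair, a 1.8-fold higher number from compound 1 to compound 3 (0.25 log units; within the scatter), places pyridin-2-yl where compound 1 has 3-fluorophenyl, and this exchange on the saturated chain carbon gives no difference that can be told from the scatter, while nothing available here accounts for either step.

The compounds shown leave open whether the step from cyano to sulfamoyl would be of similar size with 3-fluorophenyl in place of pyridin-2-yl, since compound 1 has no cyano partner among them. They also leave open where other groups at this position, such as a carboxylic acid, a primary carboxamide or a methylsulfonyl group, would fall in this assay relative to cyano and sulfamoyl.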